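The source may hold more compounds than are shown below. What is called first, only, known or untested is meant among the compounds shown, and "the series" means these compounds.

Measured so far in an assay on CHO-K1 cells for antagonist activity at transient receptor potential cation channel subfamily V member 1 (Homo sapiens), read by FLIPR; on this read-out lower numbers stand for stronger inhibition and higher numbers for weaker inhibition:
compound 1 `CCCCCSc1nc(C(F)(F)F)ccc1CNC(=O)C(C)c1ccc(NS(C)(=O)=O)c(F)c1` gives 95.6 nM
compound 2 `CC(C(=O)NCc1ccc(C(F)(F)F)nc1SCCCN1CCCCC1)c1ccc(NS(C)(=O)=O)c(F)c1` gives 250 nM

Compound 2 holds the higher of these two numbers, which here means the weaker inhibition; its nearest neighbour is compound 1, and the step of a 2.6-fold higher number from compound 1 to compound 2 (0.42 log units; beyond the scatter) lies beyond the scatter. Compound 3 `CC(C(=O)NCc1ccc(C(F)(F)F)nc1SCCc1ccccc1)c1ccc(NS(C)(=O)=O)c(F)c1` is not yet measured. It differs from compound 2 in one place: phenyl in place of (piperidin-1-yl)methyl on a saturated chain carbon, two bonds along the chain from a sulfur. Within the data shown here, only one measured step bears on this change: the step of a 2.6-fold higher number from compound 1 to compound 2 (0.42 log units; beyond the scatter) came with a piperidin-1-yl being added to the chain, and compound 3 takes that ring away again while a phenyl now ends the chain. Among the measured compounds shown here, the sole comparison therefore points downward, so a step of about a 2.3-fold lower number from compound 2 to compound 3 (0.36 log units; beyond the scatter) is expected in this assay, moving back toward the number of compound 1, although nothing measured tells how the phenyl itself acts. Compound 3 is thus estimated at 110 nM, with a range from 40 nM to 300 nM.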

Compound 3, half-maximal inhibitory concentration: 111 nM
For compound 3 the middle estimate is 1.0-fold (0.00 log units) below the measured one; measured number inside the range.
By their numbers in this assay, from the lowest: compounds 1 and 3 (each within the scatter of the next); then compound 2.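

In this assay, phenyl in place of (piperidin-1-yl)methyl on the saturated chain carbon, two bonds along the chain from the sulfur, gives a 2.3-fold lower number from compound 2 to compound 3 (0.35 log units; beyond the scatter). Phenyl in place of propyl at that same carbon gives a 1.2-fold higher number from compound 1 to compound 3 (0.06 log units; within the scatter), so here a chain ending in phenyl cannot be told apart from the plain chain of compound 1, and of these three only the piperidine-ended chain of compound 2 stands apart. No measurement here explains this difference between the two rings.

The names 3-(piperidin-1-yl)propyl and phenethyl show that the chain changes along with the ring, so the effects of the two remain unseparated. From the compounds shown here alone, whether a 3-phenylpropyl chain, or a morpholine ring or dimethylamino group at the chain end, would behave like compound 2 or compound 3 stays open.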